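Trimethoxyphenyl series: replacing the 4-bromobenzyl group

This account rests on a few compounds, and the source may have more. Where it says the series, first, only, none or still open, it means among the compounds named here.

- Compound 1 `COc1ccc(CN(C(=O)CSC(=S)N2CCOCC2)c2cc(OC)c(OC)c(OC)c2)cc1` gives 4130 nM in this series
- Compound 2 `COc1ccc(CN(C(=O)CSC(=S)N2CCN(C(=O)OC(C)(C)C)CC2)c2ccccc2)cc1` gives > 20000 nM as a limit
- Compound 3 `COc1cc(N(Cc2ccc(Br)cc2)C(=O)CSC(=S)N2CCN(C(=O)OC(C)(C)C)CC2)cc(OC)c1OC` gives 11400 nM in this series

All three results come from a functional assay on HCT-116 cells (Homo sapiens) for inhibition, read by CCK-8 assay, with a stated time of 48 h (a lower number here means a stronger inhibitor, a higher number a weaker inhibitor), and are the only data available. Of the two true numbers, compound 3 at 11400 nM is the higher, and its gap to compound 1 at 4130 nM lies beyond the scatter.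

Compound 4 `COc1ccc(CN(C(=O)CSC(=S)N2CCN(C(=O)OC(C)(C)C)CC2)c2cc(OC)c(OC)c(OC)c2)cc1F` carries 3-fluoro-4-methoxyphenyl in place of 4-bromophenyl on a saturated chain carbon bound to an amide-type nitrogen. Among the measured compounds shown here, no measured pair isolates this change, so the expectation is weakly founded. An estimated step within the scatter, if anything toward a lower number, is expected (a 1.4-fold lower number from compound 3 to compound 4 (0.15 log units; within the scatter)). Compound 4 is estimated at 8000 nM (expected range 2500 nM to 20000 nM).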

Compound 4, half-maximal inhibitory concentration: 8210 nM
Estimate against measurement, compound 4: 1.0-fold (0.01 log units) below; measured number inside the range.
By their numbers in this assay, from the lowest: compounds 1, 4 and 3 (each within the scatter of the next, the first and the last beyond it). At a limit, above all of these: compound 2.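

Among the compounds shown here, replacing 4-bromophenyl with 3-fluoro-4-methoxyphenyl on a saturated chain carbon bound to an amide-type nitrogen gives the first single-place comparison. In this assay the step is a 1.4-fold lower number from compound 3 to compound 4 (0.14 log units; within the scatter), so bromine is not needed at this position to hold the level of compound 3. Nothing shown gives a cause for this step.

On these data alone, whether the fluorine and the methoxy group each contribute alone remains open. So does the outcome with a pyridine ring or a carboxylic acid on the benzyl group.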